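The source may hold more compounds than are shown below. What is called first, only, known or untested is meant among the compounds shown, and "the series" means these compounds.

Compound 1 `Cc1c(OCCCCOc2ccc(C(=O)O)cc2Cl)ccc(C(=O)CC2CCCC2)c1O`: 82.2%
Compound 2 `Cc1c(OCCCCOc2ccc(F)c(C(=O)O)c2)ccc(C(=O)C(C)C)c1O`: 74.1%

In an assay on HEK293 cells for positive allosteric modulation of metabotropic glutamate receptor 2 (Rattus norvegicus), read by thallium flux, with a stated time of 2.5 min (a higher number here means a larger maximal response, a lower number a smaller maximal response), compound 1 reaches 82.2% while compound 2 reaches 74.1%. Compound 2 has the lower of the two numbers, yet its gap to compound 1 lies within the usual scatter, so the two cannot be told apart. Compound 3 `Cc1c(OCCCCOc2ccc(F)c(C(=O)O)c2)ccc(C(=O)CC2CCCC2)c1O` is still unmeasured; it differs from compound 2 by cyclopentylmethyl in place of isopropyl on a carbonyl carbon. Since compound 1 already carries the cyclopentylmethyl group and gives 82.2%, close to compound 2, no step beyond the scatter is expected. The expected step of a number 3.9 percentage points higher from compound 2 to compound 3 (within the scatter) is small. Compound 3 is thus estimated at 78%, in the range 66% to 90%.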

Compound 3, largest response reached (reported as percent of maximum), in percent of the reference or control that the assay uses: 81%
Compound 3: the middle estimate sits 3 percentage points below what was measured; the range from low to high includes it.
By their numbers in this assay, from the lowest: compounds 2, 3 and 1 (each within the scatter of the next).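

In this assay, cyclopentylmethyl in place of isopropyl on a carbonyl carbon gives a number 6.9 percentage points higher from compound 2 to compound 3 (within the scatter), so at this position a group with a five-membered ring and one with no ring cannot be told apart. Changing the other end of the molecule, 3-carboxy-4-fluorophenyl in place of 4-carboxy-2-chlorophenyl on an oxygen on a saturated carbon, gives a number 1.2 percentage points lower from compound 1 to compound 3 (within the scatter), and the two cannot be told apart here either. Nothing available explains these results. Still open, on these data alone, is whether a phenyl or a tert-butyl group on that carbonyl carbon would also stay within the scatter.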